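Replacing One Aromatic Ring of Compound 1

A few compounds are considered here, and "the series" means these few. Any claim that something is new, unique, unknown or untested is made for them only; others in the source may bear on it.

Compound 1 `O=C(/C(=C\c1ccc(Br)c(O)c1)Sc1ccc(Br)cc1)c1ccc(Br)cc1` is the starting point. In a functional assay on DU-145 cells (Homo sapiens) for inhibition, read by trypan blue exclusion, with a stated time of 96 h (a higher number here means a weaker inhibitor of growth, a lower number a stronger inhibitor of growth), compound 1 gives 1000 nM. Among the measured compounds shown here, its only measured neighbour, compound 2 `O=C(/C(=C\c1ccc(Br)c([N+](=O)[O-])c1)Sc1ccc(Br)cc1)c1ccc(Br)cc1`, gives 1000 nM in this assay, and the step of no change at the digits printed from compound 1 to compound 2 (within the scatter), nitro in place of hydroxy on an aromatic carbon, left growth inhibition unchanged. Compound 3 `O=C(/C(=C\c1ccc(Cl)cc1Cl)Sc1ccc(Br)cc1)c1ccc(Br)cc1` differs from compound 1 by 2,4-dichlorophenyl in place of 4-bromo-3-hydroxyphenyl on a double-bonded chain carbon bound to a double-bonded chain carbon. For the measured compounds named here, no measured step covers this exchange, and the flat nitro-for-hydroxy step is the only guide. The expected step in this assay is no change at the digits printed from compound 1 to compound 3 (within the scatter). Compound 3 is therefore estimated at 1000 nM, between 300 nM and 3500 nM.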

Compound 3, concentration for 50% growth inhibition: 1000 nM
Compound 3: middle estimate and measured number agree at the digits printed; the measured number falls inside the stated range.
By their numbers in this assay, from the lowest: compounds 1, 2 and 3 (each within the scatter of the next).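

In this assay, the step of no change at the digits printed from compound 1 to compound 3 (within the scatter) goes beyond the earlier exchange of one group on this ring: the whole 4-bromo-3-hydroxyphenyl gives way to 2,4-dichlorophenyl. Growth inhibition holds even though the entering group has 0 hydrogen-bond donors and 0 hydrogen-bond acceptors, so neither the hydroxy group nor the bromine is needed at this place. Nothing available explains why this exchange leaves the value level.

The compounds shown leave open whether any group here can shift growth inhibition at all. An amine or a carboxylic acid on this ring might do so.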